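Replacing the pyrrolyl group on the shared core

The compounds below may be only part of what the source reports. "The series", "measured", "known", "first", "only" and "open" are said of these compounds alone.

Measured so far:
compound 1 `CC1(C)C=C(n2ccccc2=O)c2cc(C(=O)c3ccccc3)ccc2O1` gives 6.61 in a functional assay (aorta) with Rattus norvegicus as the target; on this read-out higher numbers stand for higher potency (the scale is a negative logarithm) and lower numbers for lower potency
compound 2 `Cc1ccc(C)n1-c1ccc2c(c1)C(n1ccccc1=O)=CC(C)(C)O2` gives 7.27 in this assay

Among the measured compounds shown here, compound 2 stands highest of the two numbers, with compound 1 as its only neighbour. For the measured compounds named here, the single measured step is a number 0.66 log units higher from compound 1 to compound 2 (beyond the scatter), a modest rise tied to a different exchange. Compound 3 `CC1(C)C=C(n2ccccc2=O)c2cc(C(=N)S)ccc2O1` differs from compound 2 by a group of 3 heavy atoms (1 carbon, 1 nitrogen, 1 sulfur; no ring) in place of a group of 7 heavy atoms (6 carbon, 1 nitrogen; one five-membered aromatic ring with 1 hetero atom), on an aromatic carbon. Going by the values given here, no measured step covers the entering group, so its direction is unknown; the prior step offers only a scale. A modest downward step of a number 0.67 log units lower from compound 2 to compound 3 (beyond the scatter) in this assay is expected. Compound 3 is expected to give 6.6 in this assay, within 5.9 to 7.3.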

Compound 3, logarithm of the reciprocal of the active concentration, log(1/C): 6.21
Compound 3: middle estimate off by 0.39 log units, on the high side; the range from low to high includes it.
By their numbers in this assay, from the lowest: compound 3; then compound 1; then compound 2.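

In this assay, the group of 3 heavy atoms with no ring ranks below both ring-bearing groups on this aromatic carbon: replacing 2,5-dimethyl-1H-pyrrol-1-yl gives a large step, a number 1.06 log units lower from compound 2 to compound 3 (beyond the scatter), and replacing benzoyl a modest one, a number 0.40 log units lower from compound 1 to compound 3 (beyond the scatter). Among these three compounds, a ring in this place goes with the higher numbers, and none goes against this. Nothing available explains the drop. On these data alone, whether the ring or the number of heavy atoms tracks with potency stays open. So does the outcome for an amine, a carboxylic acid or a longer open chain on this carbon.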